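This account rests on a few compounds, and the source may have more. Where it says the series, first, only, none or still open, it means among the compounds named here.

Of the compounds shown here, three sharing one core have been tested for how much of each cultured human blood cells tolerate over a stretch of days. Compound 1 `CCC1(Cc2ccccc2)OS(=O)(=O)C=C1OCc1ccc(Br)cc1` carries a 4-bromophenyl group, and in an ADME assay on HEL cells (Homo sapiens) for cytotoxicity, with a stated time of 3 days (a lower number here means that less compound is tolerated, a higher number that more compound is tolerated), compound 1 gives 80000 nM. Compound 2 `CCC1(Cc2ccccc2)OS(=O)(=O)C=C1OCc1ccc(C(F)(F)F)cc1` has a trifluoromethyl in place of bromo on an aromatic carbon. In this assay compound 2 gives only a limit of the assay, >= 16000 nM, so the step that the limit leaves unreadable from compound 1 to compound 2 cannot be sized. Compound 3 `CCC1(Cc2ccccc2)OS(=O)(=O)C=C1OCC=C(C)C` carries a 2-methylprop-1-en-1-yl group instead of the aromatic one, and in this assay compound 3 gives 400000 nM, the higher of the two plain numbers, the gap being a 5.0-fold higher number from compound 1 to compound 3 (0.70 log units; beyond the scatter).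

Compound 4 `CCC1(Cc2ccccc2)OS(=O)(=O)C=C1OCc1ccc(C)cc1` is the next to be tested. Against compound 3 it differs by 4-methylphenyl in place of 2-methylprop-1-en-1-yl on a saturated chain carbon bound to an oxygen on an unsaturated carbon. For the measured compounds named here, the one measured step that bears on this is the change from compound 1 to compound 3, which read a 5.0-fold higher number from compound 1 to compound 3 (0.70 log units; beyond the scatter); compound 4 roughly reverses that kind of swap, putting an aromatic ring back where the alkene sits, so a modest step back toward the number of compound 1 is expected in this assay. Compound 4 is therefore expected to give 80000 nM, between 30000 nM and 250000 nM, which would mean an expected step of a 5.0-fold lower number from compound 3 to compound 4 (0.70 log units; beyond the scatter).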

Compound 4, minimum cytotoxic concentration: >= 16000 nM
Compound 4: a limit, no number; the forecaster's own chance of this, stated with the estimate: 20%; the middle value does not contradict the limit.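

In this assay compound 4 gives >= 16000 nM, which is a limit and not a number, so its steps to compound 1, compound 2 and compound 3 cannot be read. The same limit recurs in this set: the limit of >= 16000 nM in this assay, at which 2 of the 4 values shown sit.

Left open is where compound 2 and compound 4 sit, and whether methyl, trifluoromethyl and bromo on the aromatic carbon differ at all in how much compound is tolerated.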